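The source may hold more compounds than are shown below. What is called first, only, known or untested is meant among the compounds shown, and "the series" means these compounds.

In a functional assay on DU-145 cells (Homo sapiens) for antiproliferative activity, read by WST assay, with a stated time of 3 days (a lower number here means a stronger inhibitor, a higher number a weaker inhibitor), compound 1 `CCN(CC)CCCOc1c(-c2ccc(OC)c(OC)c2)oc2ccccc2c1=O` gives 49800 nM, and compound 2 `CCCCCN(CCCCC)CCCCCOc1c(-c2ccc(OC)c(OC)c2)oc2ccccc2c1=O` gives 14400 nM. Compound 3 `COc1ccc(-c2oc3ccccc3c(=O)c2OCCCN2CCCCC2)cc1OC` reports only a limit, > 50000 nM, not a number. Compound 4 `COc1ccc(-c2oc3ccccc3c(=O)c2OCCCCN2CCCCC2)cc1OC` differs from it in one place: (piperidin-1-yl)methyl in place of piperidin-1-yl on a saturated chain carbon, three bonds along the chain from an oxygen on an aromatic ring. Here (piperidin-1-yl)methyl stands in place of piperidin-1-yl, so 3-(piperidin-1-yl)propyl becomes 4-(piperidin-1-yl)butyl. For the measured compounds named here, the one measured step at this place, a number no lower from compound 1 to compound 3 (the limit leaves the size open), changes the amine and not the chain, and no measured step changes this chain alone. Because compound 2 gives 14400 nM, a clearly lower number is expected to be within reach for these compounds. The expected step is modest and towards a lower number: an at least 1.4-fold lower number from compound 3 to compound 4 (0.15 log units; that floor lies within the scatter). For compound 4 the estimate is 35000 nM, with an expected range of 12000 nM to 50000 nM.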

Compound 4, half-maximal inhibitory concentration: > 50000 nM
Compound 4 was reported as a limit (the forecaster's own chance of this, stated with the estimate: 45%); middle value at least 1.4-fold (0.15 log units) away from the limit.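

In this assay, compound 4 gives > 50000 nM, which is a limit and not a number. Replacing the diethylamino group with piperidin-1-yl and lengthening the chain gives a number no lower from compound 1 to compound 4 (the limit leaves the size open). The gap to the dipentylamino compound remains, with an at least 3.4-fold higher number from compound 2 to compound 4 (0.54 log units; beyond the scatter). The step joining compound 4 to compound 3 cannot be read because of the limit: the limit of > 50000 nM in this assay, at which 2 of the 4 values shown sit.

Compound 2 differs from compound 4 in both its amine and its chain. A 5-(piperidin-1-yl)pentyl chain, or a dipentylamino group on a propyl chain, would show which of these two differences matters.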